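Lengthening the hydroxamic acid chain of compound 2

A few compounds are considered here, and "the series" means these few. Any claim that something is new, unique, unknown or untested is made for them only; others in the source may bear on it.

Compound 1 `COc1ccc(/C=C/C(=O)c2ccc(OCC(=O)NO)cc2)cc1`: 620 nM
Compound 2 `CC(C)=CCC/C(C)=C/CC/C(C)=C/CSc1ccccc1C(=O)NCCC(=O)NO`: 4930 nM

Among the compounds with values here, in a functional assay on HepG2 cells (Homo sapiens) for inhibition, read by MTT assay (a lower number here means a stronger inhibitor, a higher number a weaker inhibitor), compound 2 gives 4930 nM, the higher of the two numbers so far. Compound 1 gives 620 nM, and the gap between the two lies beyond the scatter.

The next compound to be measured is compound 3 `CC(C)=CCC/C(C)=C/CC/C(C)=C/CSc1ccccc1C(=O)NCCCC(=O)NO`. It differs from compound 2 as follows: (hydroxycarbamoyl)methyl in place of hydroxycarbamoyl on a saturated chain carbon, two bonds along the chain from an amide-type nitrogen. In words, (hydroxycarbamoyl)methyl stands in place of hydroxycarbamoyl on a saturated chain carbon, two bonds along the chain from an amide-type nitrogen. Cut one bond further out, this reads 2-(hydroxycarbamoyl)ethyl to 3-(hydroxycarbamoyl)propyl.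

Within the data shown here, no measured pair carries this change, so the expectation has a single anchor, compound 2 at 4930 nM. A small move toward a lower number in this assay is expected, probably within the scatter, and the estimate is a 1.6-fold lower number from compound 2 to compound 3 (0.22 log units; within the scatter). The range is kept wide and allows for a move in either direction. For compound 3 the estimated value is 3000 nM, with an expected range of 1000 nM to 8000 nM.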

Compound 3, half-maximal inhibitory concentration: 4930 nM
Compound 3: the middle estimate sits 1.6-fold (0.22 log units) below what was measured, within the range that was stated.
By their numbers in this assay, from the lowest: compound 1; then compounds 2 and 3 (each within the scatter of the next).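

In this assay, within the data shown here, going from 2-(hydroxycarbamoyl)ethyl to 3-(hydroxycarbamoyl)propyl gives no change at the digits printed from compound 2 to compound 3 (within the scatter) and provides the first reading at this position, since the earlier compounds offered no pair differing in one place. For this one pair, the chain carrying the hydroxycarbamoyl group can take the 3-(hydroxycarbamoyl)propyl form with no shift that can be told from the scatter, while the rest of the structure stays the same. Nothing in the available data accounts for this flat result.

On these data alone, the flat reading rests on a single step, so it remains open whether a longer chain such as 4-(hydroxycarbamoyl)butyl, or the shorter (hydroxycarbamoyl)methyl on the amide-type nitrogen, would still read alongside compound 2 and compound 3 in this assay or would separate from them. Also open, as far as these compounds go, is whether the hydroxycarbamoyl group itself matters at either chain length, which a carboxylic acid in its place would test against compound 2 and compound 3 as single-place comparisons.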